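Benzyl exchange on the piperidinyl urea: compound 2 to compound 4

The compounds below may be only part of what the source reports. "The series", "measured", "known", "first", "only" and "open" are said of these compounds alone.

Among the measured compounds shown here, three ureas carry numbers so far in a functional assay on KB cells (Homo sapiens) for antiproliferative activity, read by MTT assay, with a stated time of 48 h; a higher number here means a weaker inhibitor, a lower number a stronger inhibitor. Compound 1 `CN(C)C(=O)N(Cc1cccc([N+](=O)[O-])c1)Cc1ccco1` gives 23800 nM, compound 2 `CCOC(=O)N1CCC(N(Cc2cccc([N+](=O)[O-])c2)C(=O)N(C)C)CC1` gives 15600 nM, and compound 3 `CN(C)C(=O)N(Cc1ccco1)Cc1cc(Cl)ccc1O` gives 49500 nM. Compound 2 and compound 1 lie within the usual scatter of each other, while compound 3 stands beyond the scatter above compound 2. Compound 4 `CCOC(=O)N1CCC(N(Cc2cc(Cl)ccc2O)C(=O)N(C)C)CC1` is not yet measured; it differs from compound 2 by 5-chloro-2-hydroxyphenyl in place of 3-nitrophenyl on a saturated chain carbon bound to an amide-type nitrogen, the rest of compound 2 retained. For the measured compounds named here, no measured pair supplies a step to copy, though the same two groups sit on the core of compound 1, where compound 1 shows 23800 nM and compound 3 shows 49500 nM. For compound 4 a modest rise in this assay, near the edge of the scatter, is expected, a 2.1-fold higher number from compound 2 to compound 4 (0.31 log units; beyond the scatter). Compound 4 is estimated at 32000 nM, between 15000 nM and 70000 nM.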

Compound 4, half-maximal inhibitory concentration: 25700 nM
Estimate against measurement, compound 4: 1.2-fold (0.10 log units) above; low and high end bracket the measured number.
By their numbers in this assay, from the lowest: compounds 2, 1, 4 and 3 (each within the scatter of the next, the first and the last beyond it).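

In this assay, among the compounds shown here, the exchange of 3-nitrophenyl for 5-chloro-2-hydroxyphenyl on a saturated chain carbon bound to an amide-type nitrogen gives a 1.6-fold higher number from compound 2 to compound 4 (0.22 log units; within the scatter) and is the first readable step at this position. On the core of compound 2, the two groups cannot be told apart in this assay. No measurement is available that bears on this result.

Still open, going by these compounds, is whether an amine or a carboxylic acid on the aromatic ring would separate from compound 2. The effect of a longer chain between the ring and the amide-type nitrogen is also unresolved.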